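The compounds below may be only part of what the source reports. "The series", "measured", "known", "first", "only" and "open" are said of these compounds alone.

Series so far, in a functional assay on A549 cells (Homo sapiens) for cytotoxicity, with a stated time of 48 h; a lower number here means a stronger inhibitor, a higher number a weaker inhibitor:
- compound 1 `CC(C)COc1ccc2oc(/C=C/[S+](C)[O-])cc(=O)c2c1`: 1100 nM
- compound 2 `CCCCC(=O)Oc1ccc2oc(/C=C/[S+](C)[O-])cc(=O)c2c1`: 2400 nM

Compound 2, at 2400 nM, holds the higher of the two numbers. Compound 3 `CCC(=O)Oc1ccc2oc(/C=C/[S+](C)[O-])cc(=O)c2c1` differs from it by hydrogen in place of ethyl on a saturated chain carbon, two bonds along the chain from a carbonyl carbon, which is hydrogen in place of ethyl on a saturated chain carbon, two bonds along the chain from a carbonyl carbon, or butylcarbonyl to propanoyl. For the measured compounds named here, the only measured step, a 2.2-fold higher number from compound 1 to compound 2 (0.34 log units; beyond the scatter), was modest and involved a different swap, butylcarbonyl in place of isobutyl, so it bears only indirectly and gives no direction. No step beyond the scatter is expected in this assay, and the expected change is a 1.1-fold lower number from compound 2 to compound 3 (0.04 log units; within the scatter). For compound 3 the estimated value is 2200 nM, with an expected range of 1000 nM to 5000 nM.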

Compound 3, half-maximal inhibitory concentration: 2400 nM
Beside the measured number, compound 3's estimate is 1.1-fold (0.04 log units) below it; measured number inside the range.
By their numbers in this assay, from the lowest: compound 1; then compounds 2 and 3 (each within the scatter of the next).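

In this assay, butylcarbonyl to propanoyl gives no change at the digits printed from compound 2 to compound 3 (within the scatter) and so, unlike the earlier step, tests the loss of ethyl on a saturated chain carbon, two bonds along the chain from a carbonyl carbon. Propanoyl in place of isobutyl on an oxygen on an aromatic ring gives a 2.2-fold higher number from compound 1 to compound 3 (0.34 log units; beyond the scatter) and matches the gap already seen with butylcarbonyl. Open, as far as these compounds go, is whether a longer chain, or a terminal amine or carboxylic acid on the chain, would move the number beyond the scatter. No evidence on the cause of either step is available.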